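Iodo in Place of Hydrogen and Microsomal Stability

This account rests on a few compounds, and the source may have more. Where it says the series, first, only, none or still open, it means among the compounds named here.

Measured compounds, with their values in an ADME assay on microsomes from liver (Mus musculus) for metabolic stability, read by LC-MS, using NADPH, with a stated time of 30 min, tested at 1 uM; on this read-out lower numbers stand for a less stable compound and higher numbers for a more stable compound:
compound 1, `C=CC(=O)Nc1cc(Nc2ncc(I)c(Nc3ccccc3S(=O)(=O)N(C)C)n2)c(OC)cc1N(C)CCN(C)C`, gives 12%
compound 2, `C=CC(=O)Nc1cc(Nc2nccc(Nc3ccccc3S(=O)(=O)N(C)C)n2)c(OC)cc1N(C)CCN(C)C`, gives 5%
compound 3, `C=CC(=O)Nc1cc(Nc2nccc(Nc3ccccc3S(=O)(=O)C(C)C)n2)c(OC)cc1N(C)CCN(C)C`, gives 8%

All three measured compounds share one core and leave only a small fraction intact in this assay. Compound 1 differs from compound 2 by iodo in place of hydrogen on an aromatic carbon, and this change gives a number 7 percentage points higher from compound 2 to compound 1 (within the scatter). The two cores, that of compound 2 and that of compound 3, differ by isopropyl in place of dimethylamino on a sulfonyl sulfur, a difference that gives a number 3 percentage points higher from compound 2 to compound 3 (within the scatter). Among the measured compounds shown here, compound 1 and compound 3 have no step counted between them; their two values both lie at the low end of the read-out.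

Compound 4, `C=CC(=O)Nc1cc(Nc2ncc(I)c(Nc3ccccc3S(=O)(=O)C(C)C)n2)c(OC)cc1N(C)CCN(C)C`, is not yet measured. For the measured compounds named here, it differs from compound 3 by iodo in place of hydrogen on an aromatic carbon, which is the same change, at the same place, as the one from compound 2 to compound 1. Its size in this assay is therefore expected to match the earlier one: the expected step is a number 5 percentage points higher from compound 3 to compound 4 (within the scatter), resting on compound 2 and compound 1 showing a number 7 percentage points higher from compound 2 to compound 1 (within the scatter). Since that earlier step stays within the scatter, compound 4 is expected to remain as poorly stable as its neighbours. For compound 4 the estimate in this assay is 13%, with an expected range from 4% to 28%.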

Compound 4, percent of the compound remaining: 10%
For compound 4 the middle estimate is 3 percentage points above the measured one, within the range that was stated.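

In this assay, iodo in place of hydrogen on an aromatic carbon gives a number 2 percentage points higher from compound 3 to compound 4 (within the scatter), and set beside the earlier case of the same change, the two steps do not differ: the same change on two cores in this assay, a number 7 percentage points higher (within the scatter) from compound 2 to compound 1 and a number 2 percentage points higher (within the scatter) from compound 3 to compound 4, 5 percentage points apart, within the scatter of two such steps. Isopropyl in place of dimethylamino on a sulfonyl sulfur, read on the iodinated core, gives a number 2 percentage points lower from compound 1 to compound 4 (within the scatter), and this change also shows no difference between its two cores: the same change on two cores in this assay, a number 3 percentage points higher (within the scatter) from compound 2 to compound 3 and a number 2 percentage points lower (within the scatter) from compound 1 to compound 4, 5 percentage points apart, within the scatter of two such steps. Both changes therefore carry from one core to the other without a difference that this read-out can resolve, but since every one of these steps lies within the scatter, the agreement does not show that either change has a real effect on the read-out, and two cores cannot establish a rule for the wider series.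

The compounds shown leave open whether another group on the same aromatic carbon, such as chloro, methyl or a nitrile, would give a step beyond the scatter. They also leave open what a cyclopropyl group or a longer chain on the sulfonyl sulfur, or a different amine in the side chain, would do in this assay.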